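The compounds below may be only part of what the source reports. "The series", "measured", "known", "first", "only" and "open" are said of these compounds alone.

Measured so far:
- compound 1, `Cc1ccc(NC(=O)c2ccc(Oc3ccccc3)cc2)cc1C(=O)O`: 127 nM
- compound 2, `CCCCOc1ccc(C(=O)Nc2cccc(C(=O)O)c2)cc1`: 105 nM
- compound 3, `Cc1ccc(COc2cccc(C(=O)Nc3cccc(C(=O)O)c3)c2)cc1`: 1430 nM

All three were run in an assay on isolated protein for agonist activity at Bile acid receptor (Homo sapiens), read by TR-FRET, with a stated time of 3 h, in the absence of a further agent; a higher number here means that more compound is needed for the effect, a lower number that less compound is needed. Compound 2 carries the lowest number of the three, though compound 1 sits within the usual scatter of it, so no order between those two can be read. Compound 3 is another matter: its number stands well beyond the scatter from compound 2, so compound 3 needs clearly more material for the same effect. Among the compounds with values here, no single-change pair exists among the measured compounds, so no counted step is available.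

The next compound, compound 4, is `O=C(O)c1cccc(NC(=O)c2ccc(-c3ccccc3)cc2)c1`. Relative to compound 2 the change is phenyl in place of butoxy on an aromatic carbon. What leaves is a butoxy chain of four carbons and one oxygen; what enters is a six-membered aromatic ring of carbon only, at the same place, para to a large group. Within the data shown here, compound 1 shows that an oxygen-linked aromatic ring at that place gives a number close to compound 2, but no pair shows a directly attached ring.

Expectation: the step from compound 2 to compound 4 is estimated as a 1.9-fold higher number from compound 2 to compound 4 (0.28 log units; within the scatter), a modest move toward a higher number that may fall within the scatter. For compound 4 in this assay the estimate is 200 nM, with a range from 60 nM to 700 nM.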

Compound 4, half-maximal effective concentration: > 10000 nM
Compound 4 was reported as a limit; the forecaster's own chance of this, stated with the estimate: 5%; middle value at least 50-fold (1.69 log units) from the limit.
By their numbers in this assay, from the lowest: compounds 2 and 1 (each within the scatter of the next); then compound 3. At a limit, above all of these: compound 4.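

In this assay, putting phenyl in place of butoxy on an aromatic carbon gives an at least 95-fold higher number from compound 2 to compound 4 (1.97 log units; beyond the scatter), so this place on the ring does not accept any large group, and a six-membered aromatic ring of carbon only, attached directly, can cost nearly all of the measurable effect. Compound 4 is reported only as a limit, > 10000 nM, so the true size of the step stays unknown and it can be read only as a lower bound: the limit of > 10000 nM in this assay, at which 1 of the 4 values shown sits.

The change removes the oxygen, the open chain and the ring-free character of the group in one move, so this single step cannot say which of these matters. On these data alone, a plain pentyl chain on the same aromatic carbon, which keeps a chain but loses the oxygen, and a benzyl group, which sets a ring one carbon away from the core, would help separate these readings, and it also remains open whether an amine as the linking atom would behave as the oxygen of butoxy does.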